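Moving the methoxy group around the pendant ring

The compounds below may be only part of what the source reports. "The series", "measured", "known", "first", "only" and "open" are said of these compounds alone.

Among the compounds with values here, compound 1 `COc1cccc(-c2nc3ccc(C)cn3c2NC2CCCCC2)c1` is the only member of this set with an actual number in an assay on S100 cells for inhibition of Polyunsaturated fatty acid 5-lipoxygenase (Homo sapiens), read by HPLC, with stated times of 15 min and 10 min (on this read-out higher numbers stand for weaker inhibition and lower numbers for stronger inhibition), where compound 1 gives 430 nM. Compound 2 `Cc1ccc2nc(-c3ccc([N+](=O)[O-])cc3)c(NC3CCCCC3)n2c1` is the other measured member. In this assay compound 2 returns > 30000 nM, which is a limit of the measurement rather than a number (the limit of > 30000 nM in this assay, at which 1 of the 2 values shown sits). Within the data shown here, with one number and one limit, no step between measured compounds can be drawn, and compound 1 stands as the sole anchor for what follows.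

Compound 3 `COc1ccc(-c2nc3ccc(C)cn3c2NC2CCCCC2)cc1` has the same atoms as compound 1 joined differently: 4-methoxyphenyl in place of 3-methoxyphenyl on an aromatic carbon. Among the measured compounds shown here, since no measured pair describes such a relocation of the methoxy group, the size of the step from compound 1 to compound 3 in this assay is uncertain; a shift beyond the usual scatter in either direction is possible, with some weakening thought somewhat more likely than strengthening. On that footing compound 3 is expected to give about 1000 nM, with a range from 200 nM to 6000 nM, which is expected to mean a step of a 2.3-fold higher number from compound 1 to compound 3 (0.37 log units; beyond the scatter).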

Compound 3, half-maximal inhibitory concentration: 500 nM
Compound 3: middle estimate off by 2.0-fold (0.30 log units), on the high side; low and high end bracket the measured number.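

In this assay, exchanging 3-methoxyphenyl for 4-methoxyphenyl on this aromatic carbon gives a 1.2-fold higher number from compound 1 to compound 3 (0.07 log units; within the scatter), so the two placements of the methoxy group cannot be told apart on this read-out. Within the data shown here, compound 3 also supplies the first comparison in which a group on the pendant ring is exchanged while the methoxy group stays at the same place, and methoxy in place of nitro gives an at least 60-fold lower number from compound 2 to compound 3 (1.77 log units; beyond the scatter), a step far larger than the one from relocating the methoxy group. The value of compound 2 behind that step is a limit of the measurement and not a number: the limit of > 30000 nM in this assay, at which 1 of the 3 values shown sits.

The compounds shown leave open whether the methoxy group itself is needed, as against an unsubstituted phenyl, a hydroxy group or a chlorine in its place, and whether 2-methoxyphenyl would match the two placements seen here. As far as these compounds go, the cyclohexylamino group and the methyl group on the shared core stay the same in all three compounds, so the effect of a cyclopentylamino group or a longer chain there also remains open.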